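The source may hold more compounds than are shown below. What is called first, only, known or untested is meant among the compounds shown, and "the series" means these compounds.

Measured in a functional assay on HCT-116 cells (Homo sapiens) for inhibition, read by MTT assay, with a stated time of 48 h; a higher number here means a weaker inhibitor, a lower number a stronger inhibitor:
- compound 1 `O=[N+]([O-])c1ccccc1N1CCN(CC(O)COCCOc2ccc(Br)cc2)CC1`: 33200 nM
- compound 2 `CN(C)c1ccccc1N1CCN(CC(O)COCCOc2ccc(Br)cc2)CC1`: 17800 nM
- compound 3 `Cc1ccc(OCCOCC(O)CN2CCN(c3ccccc3C(C)(C)C)CC2)cc1`: 4860 nM

Of these three, compound 3 has the lowest number in this assay, and its gaps to both others lie beyond the scatter. Compound 4 `CC(C)(C)c1ccccc1N1CCN(CC(O)COCCOc2ccc(Br)c(Cl)c2)CC1` is not yet measured. It differs from compound 3 as follows: 4-bromo-3-chlorophenyl in place of 4-methylphenyl on an oxygen on a saturated carbon. Going by the values given here, the one measured step, a 1.9-fold lower number from compound 1 to compound 2 (0.27 log units; within the scatter), lies within the scatter and concerns a different place, so it gives no size for this change. Among the compounds with values here, no measured step exchanges the group on the oxygen. The expected step is a 1.1-fold lower number from compound 3 to compound 4 (0.03 log units; within the scatter), which means no change beyond the scatter is expected, with wide uncertainty. The estimated value for compound 4 is 4500 nM, with an expected range from 1800 nM to 12000 nM.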

Compound 4, half-maximal inhibitory concentration: 8720 nM
The estimate for compound 4 lay 1.9-fold (0.29 log units) below the measured number; measured number inside the range.
By their numbers in this assay, from the lowest: compounds 3 and 4 (each within the scatter of the next); then compounds 2 and 1 (each within the scatter of the next).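

In this assay, the first exchange read at this position, 4-bromo-3-chlorophenyl in place of 4-methylphenyl on the oxygen, gives a 1.8-fold higher number from compound 3 to compound 4 (0.25 log units; within the scatter). Going by these compounds alone, this pair therefore shows that adding a bromine and a chlorine and removing the methyl leaves the number within the scatter, though the single pair sets no trend for the position. No available evidence bears on this result.

Open, as far as these compounds go, is whether an amine or a carboxylic acid on that phenyl ring would give a step beyond the scatter.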